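The source may hold more compounds than are shown below. What is called first, only, known or untested is meant among the compounds shown, and "the series" means these compounds.

Measured so far in a functional assay on FM3A cells (Mus musculus) for antiproliferative activity, read by cell counting, with a stated time of 2 days; a higher number here means a weaker inhibitor, a lower number a stronger inhibitor:
- compound 1 `COc1ccc(Nc2nc(N)c(C(=O)c3ccc(Cl)cc3)s2)cc1`: 59 nM
- compound 2 `COc1ccc(Nc2nc(N)c(C(=O)c3ccc(Br)cc3)s2)cc1`: 100 nM
- compound 3 `COc1ccc(Nc2nc(N)c(C(=O)c3ccccc3OC)s2)cc1`: 52 nM

Compound 3, at 52 nM, cannot be separated from the other two compounds: the data show a 1.1-fold lower number from compound 1 to compound 3 (0.05 log units; within the scatter) and a 1.9-fold lower number from compound 2 to compound 3 (0.28 log units; within the scatter). Next in the series is compound 4 `COc1ccc(Nc2nc(N)c(C(=O)c3cccc(OC)c3)s2)cc1`, which has 3-methoxyphenyl in place of 2-methoxyphenyl on a carbonyl carbon.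

For the measured compounds named here, no measured pair isolates this change, so the data lack a direct precedent. The two steps above are the nearest evidence, as each replaces the group on the carbonyl carbon. Going by the values given here, the only other step is a 1.7-fold higher number from compound 1 to compound 2 (0.23 log units; within the scatter). All three stay within the scatter, so no step beyond the scatter is expected here, although the narrow set of compounds leaves the range wide. The expected change is a 1.3-fold higher number from compound 3 to compound 4 (0.13 log units; within the scatter). For compound 4 the estimated value is 70 nM, with an expected range from 25 nM to 200 nM.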

Compound 4, half-maximal inhibitory concentration: 50 nM
The estimate for compound 4 lay 1.4-fold (0.15 log units) above the measured number; the measured number falls inside the stated range.
By their numbers in this assay, from the lowest: compounds 4, 3, 1 and 2 (each within the scatter of the next).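

Placing 3-methoxyphenyl in place of 2-methoxyphenyl on the carbonyl carbon gives a 1.0-fold lower number from compound 3 to compound 4 (0.02 log units; within the scatter) in this assay and is the only step here that changes just where the methoxy group sits on that phenyl ring, and it does not separate the two compounds. The steps of a 1.2-fold lower number from compound 1 to compound 4 (0.07 log units; within the scatter) and a 2.0-fold lower number from compound 2 to compound 4 (0.30 log units; within the scatter) also stay within the scatter, so 3-methoxyphenyl cannot be told apart from 4-chlorophenyl or 4-bromophenyl at this position. No measurement here offers an account of this lack of separation.

Still open, as far as these compounds go, is whether a different kind of group on the carbonyl carbon, such as a phenyl ring carrying an amine or a carboxylic acid, would give a step beyond the scatter. The rest of the core is identical in all four compounds, so the effect of a change there, such as a longer chain in place of its methoxy group, is also unknown.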